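The source may report more compounds than this note shows. Statements on the series, on what has been measured and on what is new or still open speak of the compounds shown alone.

Within the data shown here, the three compounds measured so far share one core and differ only in the aryl ring hung on the carbon that carries the double bond to nitrogen. Compound 1 `Cc1c(C(=O)N/N=C\c2ccc(O)c(O)c2O)oc2cccc(O)c12` carries a 2,3,4-trihydroxyphenyl group there; in a functional assay on PC-3 cells (Homo sapiens) for inhibition (a higher number here means a weaker inhibitor, a lower number a stronger inhibitor), compound 1 gives only a limit, >= 40000 nM, not a number. Compound 2 `Cc1c(C(=O)N/N=C\c2cccc(O)c2O)oc2cccc(O)c12` carries a 2,3-dihydroxyphenyl group and in this assay compound 2 gives 12200 nM. Compound 3 `Cc1c(C(=O)N/N=C\c2ccccc2C(F)(F)F)oc2cccc(O)c12` carries a 2-trifluoromethylphenyl group and in this assay compound 3 gives 26200 nM. Among these, compound 2 has the lowest number, with compound 3 a modest way above it.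

Among the measured compounds shown here, the one step between two measured compounds that differ in a single place is an at least 3.2-fold lower number from compound 1 to compound 2 (0.51 log units; beyond the scatter), a change that removed one hydroxy group. That its starting point sits at the limit means only part of its size is known (the limit of >= 40000 nM in this assay, at which 1 of the 3 values shown sits).

Compound 4 `Cc1c(C(=O)N/N=C\c2ccc(Br)cc2O)oc2cccc(O)c12` is not yet measured. It differs from compound 2 in one place: 4-bromo-2-hydroxyphenyl in place of 2,3-dihydroxyphenyl on a carbon with a double bond to nitrogen. Again a hydroxy is lost, and a bromine enters. For the measured compounds named here, the single step seen points, for that loss, towards a lower number, so a modest drop is expected, with much uncertainty because the bromine has no precedent here. The step from compound 2 to compound 4 is therefore expected to be a 1.7-fold lower number from compound 2 to compound 4 (0.24 log units; within the scatter). For compound 4 the expected value is 7000 nM, with a range from 2500 nM to 25000 nM.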

Compound 4, half-maximal inhibitory concentration: 2050 nM
Beside the measured number, compound 4's estimate is 3.4-fold (0.53 log units) above it; the whole stated range lies above it.
By their numbers in this assay, from the lowest: compound 4; then compound 2; then compound 3. At a limit, above all of these: compound 1.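

In this assay, putting 4-bromo-2-hydroxyphenyl in place of 2,3-dihydroxyphenyl on the carbon with a double bond to nitrogen gives a 6.0-fold lower number from compound 2 to compound 4 (0.77 log units; beyond the scatter), so this position accepts a ring carrying a bromine, and the change lowers the number by more than the scatter. Among these compounds, until now, the only single change read at this position was the loss of a hydroxy group; this step also loses one and runs in the same direction, but it brings in a bromine at the same time, so the two parts of the change cannot be told apart. Nothing measured here gives a reason for the drop.

Going by these compounds, what remains open is how much of the step belongs to the bromine and how much to the lost hydroxy, which a ring with one hydroxy group and no bromine could separate. Also open, on these data alone, is whether the bromine itself matters, or whether chlorine, a methoxy group or an amine in its place would give a similar number.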